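Adding Ethyl to a Chain After a Flat Step

A few compounds are considered here, and "the series" means these few. Any claim that something is new, unique, unknown or untested is made for them only; others in the source may bear on it.

Compound 1 (`CCCCCCCCCCCCCOC1=C(O)OC(C(O)CO)C1=O`) and compound 2 (`CCCCCCCCCCCCCCOC1=C(O)OC(C(O)CO)C1=O`) share one core and differ only in a saturated chain. In a functional assay (brain) for inhibition, with Rattus norvegicus as the target (a higher number here means a weaker inhibitor, a lower number a stronger inhibitor), compound 1 gives 7400 nM and compound 2 gives 7400 nM as its reading, so compound 2 stands level with compound 1.

Compound 3 (`CCCCCCCCCCCCCCCCOC1=C(O)OC(C(O)CO)C1=O`) keeps the same core and extends the chain. The structural change from compound 2 is this one (ethyl in place of hydrogen on a saturated chain carbon, ten or more bonds along the chain from an oxygen on an unsaturated carbon), and it can also be read as ethyl to butyl.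

Going by the values given here, only one measured step bears on it, and it is a smaller change of the same kind: no change at the digits printed from compound 1 to compound 2 (within the scatter) for methyl in place of hydrogen on a saturated chain carbon. A single flat step is thin evidence, and the larger change could still behave differently. Among the compounds with values here, with no change at the digits printed from compound 1 to compound 2 (within the scatter) as the only guide, no step beyond the scatter is expected in this assay and no direction can be favoured.

The estimated change is no change at the digits printed from compound 2 to compound 3 (within the scatter) on that reasoning. In this assay compound 3 is expected at 7400 nM with an estimated range of 3500 nM to 16000 nM as its likely span.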

Compound 3, half-maximal inhibitory concentration: 6800 nM
Compound 3: middle estimate off by 1.1-fold (0.04 log units), on the high side; the range from low to high includes it.
By their numbers in this assay, from the lowest: compounds 3, 1 and 2 (each within the scatter of the next).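

The larger change behaves like the smaller one at this place: in this assay, ethyl in place of hydrogen on a saturated chain carbon, ten or more bonds along the chain from an oxygen on an unsaturated carbon, gives a 1.1-fold lower number from compound 2 to compound 3 (0.04 log units; within the scatter). Read across the whole span, propyl in place of hydrogen at that same place gives a 1.1-fold lower number from compound 1 to compound 3 (0.04 log units; within the scatter), so the flat result now holds over a bigger difference in the chain than the first pair alone could test, and all three compounds stay within the scatter of one another. Nothing measured here explains why the reading stays flat.

Whether that flat reading lasts is open for a longer chain, and equally for a much shorter chain such as butyl, as these three compounds cover only a narrow range of chain lengths. An amine or a carboxylic acid placed on the chain would be a different kind of change, and compounds that carry only saturated carbon there give no guide to how it would read.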